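The source may hold more compounds than are shown below. What is called first, only, known or untested is meant among the compounds shown, and "the series" means these compounds.

Measured in a functional assay on A549 cells (Homo sapiens) for cytotoxicity, read by MTT assay, with a stated time of 72 h; a lower number here means a stronger inhibitor, a higher number a weaker inhibitor:
- compound 1 `COc1ccc(/C=C2\CCC/C(=C\c3ccc(Cl)cc3)C2=O)cc1OC`: 10100 nM
- compound 2 `COc1ccc(/C=C2\CCC/C(=C\c3ccc(OC)c(OC)c3)C2=O)cc1`: > 20000 nM (a limit of the assay, not a number)
- compound 3 `COc1ccc(/C=C2\CCC/C(=C\c3cccc(O)c3)C2=O)cc1OC`: 4300 nM

Compound 3 holds the lower of the two actual numbers in this assay, and compound 1 holds the other. The next compound is compound 4 `COc1ccc(/C=C2\CCC/C(=C\c3cc(Cl)cc(Cl)c3)C2=O)cc1OC`. The difference from compound 3 is 3,5-dichlorophenyl in place of 3-hydroxyphenyl on a double-bonded chain carbon bound to a double-bonded ring carbon: 3,5-dichlorophenyl in place of 3-hydroxyphenyl, on a double-bonded chain carbon bound to a double-bonded ring carbon.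

The closest measured comparison is a 2.3-fold lower number from compound 1 to compound 3 (0.37 log units; beyond the scatter), where 3-hydroxyphenyl replaced 4-chlorophenyl at that same place. Read in reverse, it points to a higher number once chlorine-bearing phenyl returns. The step of an at least 4.6-fold lower number from compound 2 to compound 3 (0.66 log units; beyond the scatter) leans the same way but starts from a limit. For the measured compounds named here, no measured compound carries 3,5-dichlorophenyl, so this rests on a single modest step and the range stays wide.

A modest rise in this assay is expected, estimated as a 1.9-fold higher number from compound 3 to compound 4 (0.27 log units; within the scatter). The estimate for compound 4 is 8000 nM, with an expected range of 3000 nM to 20000 nM.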

Compound 4, half-maximal inhibitory concentration: 5500 nM
The estimate for compound 4 lay 1.5-fold (0.16 log units) above the measured number, and the stated range covers the measured number.
By their numbers in this assay, from the lowest: compounds 3, 4 and 1 (each within the scatter of the next, the first and the last beyond it). At a limit, above all of these: compound 2.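

In this assay, a phenyl group bearing a hydrogen-bond donor and acceptor (3-hydroxyphenyl) and one bearing neither (3,5-dichlorophenyl) are not separated at this place: a 1.3-fold higher number from compound 3 to compound 4 (0.11 log units; within the scatter). The second comparison, a 1.8-fold lower number from compound 1 to compound 4 (0.26 log units; within the scatter), also leaves 3,5-dichlorophenyl unseparated from 4-chlorophenyl, so compound 4 cannot be told apart from either compound 3 or compound 1, although those two lie beyond the scatter of each other. The remaining step, an at least 3.6-fold lower number from compound 2 to compound 4 (0.56 log units; beyond the scatter), starts from a limit and not from a number: the limit of > 20000 nM in this assay, at which 1 of the 4 values shown sits.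

Going by these compounds, it remains open whether an amine or a carboxylic acid on the phenyl ring at this place would stay in the same range. Also open, on these data alone, is whether the match between 3,5-dichlorophenyl and 3-hydroxyphenyl holds when the other half of the shared core changes.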